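The compounds below may be only part of what the source reports. "The series", "measured", "known", "first", "only" and "open" are said of these compounds alone.

Three small fused-ring compounds, all built on a shared core, have been tested in a functional assay for inhibition, with Homo sapiens as the target; a lower number here means a stronger inhibitor, a higher number a weaker inhibitor. Compound 1 `CSc1nncc2c(C(C)C)ncn12` gives only a limit of the assay, > 48000 nM. Compound 2 `CCc1nc(C)c2cnnc(SC)n12` likewise gives only a limit, > 48000 nM. Compound 3 `Cc1ncn2c(S)nncc12` also stops at a limit, > 48000 nM. Nothing therefore separates these three: all sit at the limit of > 48000 nM in this assay, at which 3 of the 3 values shown sit, and no real number has been reached for any of them.

Compound 4 `CSc1nncc2c(C)ncn12` differs from compound 3 by one change: methyl in place of hydrogen on a sulfur. Compounds 1 and 2 already carry that methylsulfanyl group and still give only limits in this assay, so no step beyond the scatter is expected; the step that the limit leaves unreadable from compound 3 to compound 4 is an estimate only. Compound 4 is expected to give 70000 nM, within 25000 nM to 200000 nM, most likely reported again as a limit.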

Compound 4, half-maximal inhibitory concentration: > 48000 nM
Compound 4: only a limit was reported; the forecaster's own chance of this, stated with the estimate: 85%; the middle value lies beyond the limit too.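

Compound 4 also stops at a limit, so no step between it and compound 1, compound 2 or compound 3 can be read: the limit of > 48000 nM in this assay, at which 4 of the 4 values shown sit.

Which change to the shared core, if any, would give a real number in this assay stays open.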